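Ethyl to Acrylamide on the Anilide Ring of a Quinazoline

This account rests on a few compounds, and the source may have more. Where it says the series, first, only, none or still open, it means among the compounds named here.

Compound 1 `O=C(CSc1nc(Nc2ccccc2)c2ccccc2n1)Nc1cccc(Cl)c1` — 14300 nM
Compound 2 `CCc1cccc(NC(=O)CSc2nc(Nc3ccccc3)c3ccccc3n2)c1` — 15800 nM

Of the compounds shown here, two sharing a common core have been measured in a functional assay on MGC-803 cells (Homo sapiens) for inhibition, read by MTT assay, with a stated time of 72 h; a lower number here means a stronger inhibitor, a higher number a weaker inhibitor. Compound 1 `O=C(CSc1nc(Nc2ccccc2)c2ccccc2n1)Nc1cccc(Cl)c1` gives 14300 nM in this assay, and compound 2 `CCc1cccc(NC(=O)CSc2nc(Nc3ccccc3)c3ccccc3n2)c1` gives 15800 nM. Among the compounds with values here, the only measured step, a 1.1-fold higher number from compound 1 to compound 2 (0.04 log units; within the scatter), is within the scatter, so compound 2 stands with the higher of the two numbers but is not separable from compound 1 on this evidence.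

Compound 3 `C=CC(=O)Nc1cccc(NC(=O)CSc2nc(Nc3ccccc3)c3ccccc3n2)c1` is the next compound in the series and has not yet been measured. It differs from compound 2 in one place: (vinylcarbonyl)amino in place of ethyl on an aromatic carbon. Within the data shown here, the one measured step, a 1.1-fold higher number from compound 1 to compound 2 (0.04 log units; within the scatter), concerns an exchange of chloro for ethyl at the same position and gives no guide to what an amide-bearing group of this kind will do; no measured step bears directly on this change. With nothing to point in either direction, the expected step from compound 2 to compound 3 in this assay is a 1.6-fold lower number from compound 2 to compound 3 (0.20 log units; within the scatter), essentially no step beyond the scatter, though with a wide range. Compound 3 is therefore estimated to give 10000 nM in this assay, with a plausible range from 2500 nM to 40000 nM.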

Compound 3, half-maximal inhibitory concentration: 7310 nM
Compound 3: the middle estimate sits 1.4-fold (0.14 log units) above what was measured, and the stated range covers the measured number.
By their numbers in this assay, from the lowest: compounds 3, 1 and 2 (each within the scatter of the next, the first and the last beyond it).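

In this assay, within the data shown here, putting (vinylcarbonyl)amino in place of ethyl on the same aromatic carbon gives a 2.2-fold lower number from compound 2 to compound 3 (0.33 log units; beyond the scatter) and is the first step at this position to pass beyond the scatter, though only modestly. The earlier exchange of chloro for ethyl had shown no separable difference, so this position is not wholly indifferent to what it carries, at least when ethyl is the group replaced. The comparison with chloro is weaker, however: the same group in place of chloro gives a 2.0-fold lower number from compound 1 to compound 3 (0.29 log units; within the scatter) and stays within the scatter, so compound 3 is separated from compound 2 but not from compound 1, and no evidence here explains the shift seen from ethyl.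

The compounds shown leave open whether the vinyl double bond matters at all, a question that a propanoylamino or acetylamino group at this position would address, and whether a plain amine or a carboxylic acid on the same carbon would match compound 3. They also leave open whether a longer chain carrying the same vinylcarbonyl group would move the number further in either direction in this assay, or whether the step seen here is the limit of what this position offers.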